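Chloro removal from compound 3: expected step to compound 4

The compounds below may be only part of what the source reports. "The series", "measured", "known", "first", "only" and "open" are said of these compounds alone.

Measured in a functional assay on HCT-116 cells (Homo sapiens) for cytotoxicity, read by MTT assay; a higher number here means a weaker inhibitor, a lower number a stronger inhibitor:
- compound 1 `Cc1cc(O)c(C(=O)/C=C/c2ccccc2)c(=O)o1`: > 100000 nM (a limit of the assay, not a number)
- compound 2 `Cc1cc(O)c(C(=O)/C=C/c2ccccc2[N+](=O)[O-])c(=O)o1`: > 100000 nM (a limit of the assay, not a number)
- compound 3 `Cc1cc(O)c(C(=O)/C=C/c2ccc(Cl)cc2Cl)c(=O)o1`: 88700 nM

For the measured compounds named here, compound 3 carries the only true number, 88700 nM. The other two entries sit at one shared bound, (the limit of > 100000 nM in this assay, at which 2 of the 3 values shown sit).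

Compound 4 `Cc1cc(O)c(C(=O)/C=C/c2ccccc2Cl)c(=O)o1` is the next case, and it differs from compound 3 as follows: hydrogen in place of chloro on an aromatic carbon. It keeps the remaining chloro group of compound 3, a group that compound 1 lacks.

Going by the values given here, the only measured step is a step that the two limits leave unreadable from compound 1 to compound 2. That step has no readable size, so no size can be carried over to the present change. Among the compounds with values here, the data contain no measured step for the loss of a chloro group.

The expectation in this assay therefore rests on the value of compound 3 and on the bound reached by compound 1 and compound 2. No change beyond the scatter is expected, with any drift more likely towards weaker inhibition. The expected step is a 1.1-fold higher number from compound 3 to compound 4 (0.05 log units; within the scatter). A report of only a limit is quite possible for this compound.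

For compound 4 the estimate is 100000 nM, with an expected range from 60000 nM to 170000 nM.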

Compound 4, half-maximal inhibitory concentration: > 100000 nM
Compound 4: only a limit was reported; the forecaster's own chance of this, stated with the estimate: 55%; the middle value sits exactly at the limit.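

For the compounds shown here, removing the chloro group from this aromatic carbon, para to a large group and meta to the remaining chloro group, gives an at least 1.1-fold higher number from compound 3 to compound 4 (0.05 log units; that floor lies within the scatter) in this assay, the first step with a readable floor. Compound 4 gives > 100000 nM, which is a limit of the assay and not a number. The true size of the step may therefore be larger than its floor, so a real loss from removing this chloro group is neither shown nor excluded; the steps from compound 1 and from compound 2 to compound 4 cannot be read, and compound 3 remains the only compound with a true number, with the others at one shared bound: the limit of > 100000 nM in this assay, at which 3 of the 4 values shown sit.

The compounds shown leave open whether the remaining chloro group of compound 4 contributes anything in this assay, as no compound here isolates a chloro group at the position para to a large group. They also leave open whether a methoxy group, an amine or a carboxylic acid on that same aromatic carbon would give a true number rather than a limit.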